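Adding a fluoro group to compound 2

This account rests on a few compounds, and the source may have more. Where it says the series, first, only, none or still open, it means among the compounds named here.

Measured in an ADME assay on MT4 cells (Homo sapiens) for cytotoxicity, read by MTT assay, with a stated time of 4 days; on this read-out lower numbers stand for higher toxicity in this test and higher numbers for lower toxicity in this test:
Compound 1 `Nc1ccc2oc(-c3ccccc3)c(O)c(=O)c2c1` gives 217000 nM
Compound 2 `COc1c(-c2ccccc2)oc2ccc(N)cc2c1=O` gives 126000 nM

The numbers for the two measured compounds lie within the scatter of each other, so compound 2 cannot be told apart from compound 1. Compound 3 `COc1c(-c2ccc(F)cc2)oc2ccc(N)cc2c1=O` differs from compound 2 by fluoro in place of hydrogen on an aromatic carbon, para to a large group, which turns phenyl into 4-fluorophenyl (fluoro in place of hydrogen on an aromatic carbon). Among the compounds with values here, the only measured step, a 1.7-fold lower number from compound 1 to compound 2 (0.24 log units; within the scatter), is methyl in place of hydrogen on an oxygen, a different change, and it bears on this one only loosely. Within the data shown here, no measured pair tests a fluoro group. In this assay no shift beyond the scatter is therefore expected, and the estimated step is a 1.1-fold lower number from compound 2 to compound 3 (0.02 log units; within the scatter). The estimate for compound 3 is 120000 nM, with an expected range from 60000 nM to 230000 nM.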

Compound 3, half-maximal cytotoxic concentration: 141000 nM
Compound 3: middle estimate off by 1.2-fold (0.07 log units), on the low side; the range from low to high includes it.
By their numbers in this assay, from the lowest: compounds 2, 3 and 1 (each within the scatter of the next).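

In this assay, putting fluoro in place of hydrogen on this aromatic carbon, para to a large group, gives a 1.1-fold higher number from compound 2 to compound 3 (0.05 log units; within the scatter), so 4-fluorophenyl cannot be told apart from phenyl on this read-out. Within the data shown here, the earlier pair differed only by a methyl in place of hydrogen on an oxygen, whereas compound 3 gives the only reading at this aromatic carbon, and there too the step stays within the scatter. Nothing available explains this result or links it to any property of the fluoro group.

The compounds shown leave open whether a larger group at this place, such as trifluoromethyl, methoxy or a carboxylic acid, would also stay within the scatter. They also leave open what an amide in place of the amine on the shared core would do.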